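A few compounds are considered here, and "the series" means these few. Any claim that something is new, unique, unknown or untested is made for them only; others in the source may bear on it.

Compound 1, `CC(C)=CCC1Cc2c(OC(=O)Nc3ccc(F)cc3F)cc(=O)n(CCCO)c2CC1(C)C`: 69.7%
Compound 2, `CC(C)=CCC1Cc2c(OC(=O)Nc3ccc(Cl)cc3)cc(=O)n(CCCO)c2CC1(C)C`: 49.8%

Of the compounds shown here, two have been measured in a functional assay on PANC-1 cells (Homo sapiens) for inhibition, read by MTT assay, with a stated time of 24 h, tested at 10 uM; on this read-out lower numbers stand for less inhibition and higher numbers for more inhibition at the one concentration tested (going by the name of the read-out). Compound 1 gives 69.7%, and compound 2 gives 49.8%. On these two numbers compound 1 stands highest; its nearest neighbour is compound 2, and the step of a number 19.9 percentage points lower from compound 1 to compound 2 (beyond the scatter) lies beyond the scatter.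

Compound 3, `CC(C)=CCC/C(C)=C/CC1Cc2c(OC(=O)Nc3ccc(F)cc3F)cc(=O)n(CCCO)c2CC1(C)C`, has not yet been measured in this assay. It differs from compound 1 in one place: 3-methylbut-2-en-1-yl in place of hydrogen on a saturated chain carbon bound to a double-bonded chain carbon. The shared core, the hydroxypropyl chain and the carbamate bearing the 2,4-difluorophenyl group are unchanged; only the 3-methylbut-2-en-1-yl chain grows to 3,7-dimethylocta-2,6-dien-1-yl.

Going by the values given here, the one measured step, from compound 1 to compound 2, concerns the aryl group on the carbamate nitrogen and not the chain, so no measured step bears on the change from compound 1 to compound 3. With nothing in the data to point either way, compound 3 is expected to give a number close to that of compound 1, and the expected step of a number 4.7 percentage points lower from compound 1 to compound 3 (within the scatter) is estimated to lie within the scatter. Compound 3 is therefore estimated at 65%, with a range from 40% to 85%.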

Compound 3, a percentage reported as inhibition, at one concentration (the size of the read-out at that concentration, not a potency): 33.7%
For compound 3 the middle estimate is 31.3 percentage points above the measured one; measured number below the stated range.
By their numbers in this assay, from the lowest: compound 3; then compound 2; then compound 1.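

In this assay the new result shows that the saturated chain carbon bound to a double-bonded chain carbon is not a neutral place for growth: extending 3-methylbut-2-en-1-yl to 3,7-dimethylocta-2,6-dien-1-yl gives a number 36 percentage points lower from compound 1 to compound 3 (beyond the scatter) with the 2,4-difluorophenyl carbamate held unchanged. Going by these compounds alone, the only step available before, a number 19.9 percentage points lower from compound 1 to compound 2 (beyond the scatter) on the same read-out, concerned the aryl group on the carbamate nitrogen, so it is now clear that the chain also moves the number, and by a large step on this one change. No measurement at hand gives a reason for this drop.

With only these two chain lengths, the compounds shown do not tell whether inhibition falls steadily as the chain grows or whether the added 3-methylbut-2-en-1-yl unit matters in some more specific way, and a saturated chain such as 3-methylbutyl, or a chain ending in an amine or a carboxylic acid, would speak to that. From the compounds shown here alone, it also stays open whether the same extension would lower the number to a similar extent with the 4-chlorophenyl group of compound 2 on the carbamate.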